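This account rests on a few compounds, and the source may have more. Where it says the series, first, only, none or still open, it means among the compounds named here.

Compound 1 `O=C1NCCC12CCN(c1c(Cl)cncc1-c1ccoc1)CC2`: 750 nM
Compound 2 `O=C1NCCC12CCN(c1c(Cl)cncc1-c1cc[nH]c1)CC2`: 1050 nM
Compound 3 `Cc1ccsc1-c1cncc(Cl)c1N1CCC2(CCNC2=O)CC1`: 910 nM

In a functional assay on MV4-11 cells (Homo sapiens) for inhibition, read by resazurin assay, with a stated time of 72 h (a lower number here means a stronger inhibitor of growth, a higher number a weaker inhibitor of growth), compound 3 gives 910 nM, and it cannot be told apart from the other two: there is a 1.2-fold higher number from compound 1 to compound 3 (0.08 log units; within the scatter) and a 1.2-fold lower number from compound 2 to compound 3 (0.06 log units; within the scatter). Compound 4 `O=Cc1ccc(-c2cncc(Cl)c2N2CCC3(CCNC3=O)CC2)s1` has 5-formylthiophen-2-yl in place of 3-methylthiophen-2-yl on an aromatic carbon. The measured steps at this same place, including a 1.4-fold higher number from compound 1 to compound 2 (0.15 log units; within the scatter), all exchange one five-membered aromatic ring for another, and all are small. Going by the values given here, none of the measured compounds carries a formyl group, so the data leave some uncertainty. The expected result is a 1.1-fold lower number from compound 3 to compound 4 (0.03 log units; within the scatter), with no step beyond the scatter. For compound 4 the estimate is 850 nM, within an expected range of 350 nM to 2000 nM.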

Compound 4, concentration for 50% growth inhibition: 750 nM
For compound 4 the middle estimate is 1.1-fold (0.05 log units) above the measured one; measured number inside the range.
By their numbers in this assay, from the lowest: compounds 1, 4, 3 and 2 (each within the scatter of the next).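

Compound 4 shows that this position on the shared core also accepts a five-membered aromatic ring carrying a formyl group, a group with a double bond outside the ring: in this assay there is a 1.2-fold lower number from compound 3 to compound 4 (0.08 log units; within the scatter) and a 1.4-fold lower number from compound 2 to compound 4 (0.15 log units; within the scatter) and no change at the digits printed from compound 1 to compound 4 (within the scatter). Going by these compounds alone, all the ring exchanges at this position so far therefore stay within the scatter. Nothing measured here explains this flat result. As far as these compounds go, whether an amine or a carboxylic acid on this ring would stay within the scatter remains open. So does the effect of replacing the five-membered ring with a phenyl ring.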